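The source may hold more compounds than are shown below. What is called first, only, known or untested is meant among the compounds shown, and "the series" means these compounds.

Measured so far in a functional assay for inhibition, with Homo sapiens as the target; on this read-out lower numbers stand for stronger inhibition and higher numbers for weaker inhibition:
- compound 1 `CC#CCC(C)[C@H](O)/C=C/[C@H]1[C@H](O)C[C@]2(CCCCCO)C/C(=C/CCCC(=O)O)C[C@H]12` gives 11000 nM
- compound 2 `CC#CCC(C)[C@H](O)/C=C/[C@H]1[C@H](O)C[C@]2(CCCCCO)C/C(=C\CCCC(=O)O)C[C@H]12` gives 7000 nM

The series holds a single measured step, a 1.6-fold lower number from compound 1 to compound 2 (0.20 log units; within the scatter), so the two values are not separated and compound 1 has no distinct rank. Compound 3 `CC#CCC(C)[C@H](O)/C=C/[C@H]1[C@H](O)C[C@]2(C#CCCCI)C/C(=C/CCCC(=O)O)C[C@H]12` is still unmeasured and keeps the double-bond geometry of compound 1 . The change is 5-iodopent-1-yn-1-yl in place of 5-hydroxypentyl on a saturated ring carbon. The measured step concerns the double bond and not this group, so it gives no size for the present change. The anchor is therefore compound 1 at 11000 nM. No shift beyond the scatter is expected in this assay, and no direction can be argued, so the range stays wide. The expected step is a 1.4-fold lower number from compound 1 to compound 3 (0.14 log units; within the scatter). For compound 3 the estimate is 8000 nM, with an expected range of 1500 nM to 40000 nM.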

Compound 3, half-maximal inhibitory concentration: 200 nM
Compound 3: middle estimate off by 40-fold (1.60 log units), on the high side; the whole stated range lies above it.
By their numbers in this assay, from the lowest: compound 3; then compounds 2 and 1 (each within the scatter of the next).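

Unlike the double-bond step, which stayed within the scatter, the group on this saturated ring carbon clearly moves the read-out in this assay: 5-iodopent-1-yn-1-yl in place of 5-hydroxypentyl gives a 55-fold lower number from compound 1 to compound 3 (1.74 log units; beyond the scatter). The two groups match in heavy-atom count, while the entering group carries an iodine and a triple bond and has no hydrogen-bond donor or acceptor. Nothing measured here bears on why the number falls.

The step bundles three changes, the iodine, the triple bond and the loss of the hydroxy group, and the compounds shown do not assign it to any one of them; 5-iodopentyl and 5-hydroxypent-1-yn-1-yl would separate them. Also open, as far as these compounds go, are an amine or a carboxylic acid at the chain end, a longer chain, and whether double-bond geometry matters with the new group.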